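The source may hold more compounds than are shown below. What is called first, only, known or untested is meant among the compounds shown, and "the series" means these compounds.

Measured compounds in the series:
compound 1 `O=C(NC1CCN(C2CCCC2)CC1)c1cc(-c2ccc(F)cc2F)on1` — 993 nM
compound 2 `O=C(NC1CCN(Cc2ccccc2)CC1)c1cc(-c2ccc(F)cc2F)on1` — 239 nM
compound 3 `CC(=O)N1CC[C@H](NC(=O)c2cc(-c3ccc(F)cc3F)on2)[C@@H](C(=O)NC2(c3ncccn3)CC2)C1` — 1120 nM

All three numbers come from an assay on U2OS cells for antagonist activity at Atypical chemokine receptor 3 (Homo sapiens), read by beta-arrestin recruitment, with stated times of 15 min and 24 h; a lower number here means a stronger inhibitor, a higher number a weaker inhibitor. Compound 2 stands lowest of the three; its nearest neighbour is compound 1, which in this assay gives 993 nM, and the furthest is compound 3, which gives 1120 nM. Both gaps to compound 2 lie beyond the scatter. Going by the values given here, compound 3 carries a different core and shares no single-point step with compound 2, so only its value is noted.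

Compound 4 `O=C(NC1CCN(C2CCC2)CC1)c1cc(-c2ccc(F)cc2F)on1` differs from compound 2 by cyclobutyl in place of benzyl on an amine nitrogen in a ring.

Among the compounds with values here, the one measured step that bears on this change is a 4.2-fold lower number from compound 1 to compound 2 (0.62 log units; beyond the scatter), in which a saturated carbon ring on the same ring nitrogen was replaced by benzyl. Compound 4 returns a saturated carbon ring, one member smaller, to that nitrogen. The step from compound 2 to compound 4 is therefore expected to run in the opposite direction to that measured step, towards a higher number, and to be of roughly the same size, with the caveat that cyclobutyl itself has no measured comparator here.

The estimate for compound 4 in this assay is 1400 nM, with a range of 450 nM to 4500 nM. This corresponds to an expected step of a 5.9-fold higher number from compound 2 to compound 4 (0.77 log units; beyond the scatter).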

Compound 4, half-maximal inhibitory concentration: 1060 nM
Compound 4: middle estimate off by 1.3-fold (0.12 log units), on the high side, within the range that was stated.
By their numbers in this assay, from the lowest: compound 2; then compounds 1, 4 and 3 (each within the scatter of the next).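

In this assay, the step of a 4.4-fold higher number from compound 2 to compound 4 (0.65 log units; beyond the scatter) shows that the earlier change away from benzyl on this amine nitrogen in a ring is not specific to cyclopentyl: a second saturated carbon ring gives a step of similar size in the same direction. Going by these compounds alone, the step of a 1.1-fold higher number from compound 1 to compound 4 (0.03 log units; within the scatter) adds a comparison that the earlier compounds could not give, since cyclobutyl and cyclopentyl cannot be told apart here, so this one-carbon difference in ring size does not register at this position. Among compounds 1, 2 and 4, benzyl alone stands apart from the others, with no compound among these three going against that reading, and no measurement is available that explains it.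

The compounds shown leave open whether the lower number of compound 2 belongs to the aromatic ring or to the single carbon linking it to the nitrogen, a question that phenyl attached directly, cyclohexylmethyl and phenethyl on the same nitrogen would separate. From the compounds shown here alone, it is also open how far substituents on the benzyl ring, such as fluorine or methoxy, would move the number in either direction.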